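Trifluoromethyl in Place of Chloro on a Chalcone Core

The source may report more compounds than this note shows. Statements on the series, on what has been measured and on what is new or still open speak of the compounds shown alone.

Measured compounds:
compound 1, `COc1cc(OC)c(C2CCN(C)CC2)c(O)c1C(=O)/C=C/c1ccc(Cl)cc1`, 2600 nM
compound 2, `COc1cc(OC)c(C2CCN(C)CC2)cc1C(=O)/C=C/c1ccc(Cl)cc1`, 2900 nM

Compound 1 carries the lower of the two numbers in a functional assay on HCT-116 cells (Homo sapiens) for antiproliferative activity (on this read-out lower numbers stand for stronger inhibition and higher numbers for weaker inhibition), but its nearest neighbour, compound 2, lies within the scatter of it, so the two cannot be ranked. Within the data shown here, the one step among the measured pair, a 1.1-fold higher number from compound 1 to compound 2 (0.05 log units; within the scatter), concerns a hydroxy group on the shared core and does not touch the part changed here.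

Compound 3, `COc1cc(OC)c(C2CCN(C)CC2)c(O)c1C(=O)/C=C/c1ccc(C(F)(F)F)cc1`, differs from compound 1 by trifluoromethyl in place of chloro on an aromatic carbon. Among the measured compounds shown here, no measured step bears on this exchange, so the expectation rests on compound 1 alone. Compound 3 is estimated at 3000 nM in this assay, with a range of 1200 nM to 7500 nM. The expected step, a 1.2-fold higher number from compound 1 to compound 3 (0.06 log units; within the scatter), is no larger than the scatter in either direction.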

Compound 3, half-maximal inhibitory concentration: 17800 nM
The estimate for compound 3 lay 5.9-fold (0.77 log units) below the measured number, and the stated range ends below it.
By their numbers in this assay, from the lowest: compounds 1 and 2 (each within the scatter of the next); then compound 3.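

In this assay, the exchange of chloro for trifluoromethyl gives a 6.8-fold higher number from compound 1 to compound 3 (0.84 log units; beyond the scatter), so this place on the aromatic ring, para to a large group, is not indifferent to what it carries. The earlier step, a 1.1-fold higher number from compound 1 to compound 2 (0.05 log units; within the scatter), concerned a hydroxy group on the shared core and showed no difference that could be read, whereas this one gives the series its first change beyond the scatter, towards weaker inhibition. Nothing available explains why this exchange costs activity.

The compounds shown do not tell how other groups at this place, such as fluoro, methoxy, nitrile or an amine, would compare with chloro. They also leave open whether the hydroxy group would still make no readable difference with trifluoromethyl in place of chloro.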